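Swapping benzyl for a branched hydroxy side chain

A few compounds are considered here, and "the series" means these few. Any claim that something is new, unique, unknown or untested is made for them only; others in the source may bear on it.

Measured compounds:
compound 1 `O[C@@H]1Cc2ccccc2[C@H]1NC1CCN(CCCc2c[nH]c3ccc(-n4cnnc4)cc23)CC1` gives 13 nM in an assay on CHO cells for agonist activity at 5-hydroxytryptamine receptor 1D (Homo sapiens), read by GTPgammaS binding; on this read-out higher numbers stand for an effect only at larger amounts of compound and lower numbers for an effect already at smaller amounts
compound 2 `c1ccc(CNC2CCN(CCCc3c[nH]c4ccc(-n5cnnc5)cc34)CC2)cc1` gives 7.6 nM in this assay

For the measured compounds named here, compound 2 stands at the lower of the two numbers in this assay, but the only measured step, a 1.7-fold lower number from compound 1 to compound 2 (0.23 log units; within the scatter), lies within the scatter, so neither compound can be ranked above the other. Compound 3 `CC(CO)(NC1CCN(CCCc2c[nH]c3ccc(-n4cnnc4)cc23)CC1)c1ccccc1` carries 1-(hydroxymethyl)-1-phenylethyl in place of benzyl on an amine nitrogen. The step from compound 1 to compound 2 bears on this change, since it also swapped the group on this amine nitrogen, and it hardly moved the number. A small step at most is therefore expected, a 1.8-fold higher number from compound 2 to compound 3 (0.27 log units; within the scatter), with compound 3 estimated at 14 nM, ranging from 5 nM to 45 nM.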

Compound 3, half-maximal effective concentration: 3.4 nM
Estimate against measurement, compound 3: 4.1-fold (0.61 log units) above; the whole stated range lies above it.
By their numbers in this assay, from the lowest: compound 3; then compounds 2 and 1 (each within the scatter of the next).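

In this assay, changing the group on this amine nitrogen now moves the number beyond the scatter, and it moves down for the branched 1-(hydroxymethyl)-1-phenylethyl group, both against benzyl (a 2.2-fold lower number from compound 2 to compound 3 (0.35 log units; beyond the scatter)) and against 2-hydroxy-2,3-dihydro-1H-inden-1-yl (a 3.8-fold lower number from compound 1 to compound 3 (0.58 log units; beyond the scatter)). The earlier step between those two groups stayed within the scatter, so this position had not yet shown any readable change. Nothing measured here accounts for the lower number.

The compounds shown leave open whether the hydroxymethyl part matters, since 1-methyl-1-phenylethyl does not appear among them. Also open, going by these compounds, is how an amine or a carboxylic acid in that place would read.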